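The compounds below may be only part of what the source reports. "The series", "measured", "known", "first", "only" and "open" are said of these compounds alone.

Of the compounds shown here, two of the shared core have been tested in a functional assay on thoracic aorta for antagonist activity at thromboxane A2 receptor (Rattus norvegicus); a lower number here means a stronger inhibitor, a higher number a weaker inhibitor. Compound 1 `CC(C)c1ccc2c(CNC(=O)CNC(=O)c3ccc(Cl)cc3)cc(C(=O)O)c-2cc1` gives only > 100000 nM, which is a limit of the assay rather than a number. For the measured compounds named here, compound 2 `CC(C)c1ccc2c(CCC/C=N/N=C(\S)Nc3ccccc3)cc(C(=O)O)c-2cc1` gives 590000 nM in this assay, the only real number among the two results. Compound 3 `CC(C)c1ccc2c(CCC/C=N/N=C(\S)Nc3ccc(Cl)cc3)cc(C(=O)O)c-2cc1` differs from compound 2 by one change, (chloro in place of hydrogen on an aromatic carbon), chloro in place of hydrogen on an aromatic carbon. Going by the values given here, no measured step exists for this change. The step of a 1.5-fold lower number from compound 2 to compound 3 (0.17 log units; within the scatter) is expected to stay within the usual scatter. Compound 3 is estimated at 400000 nM, between 100000 nM and 1500000 nM.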

Compound 3, half-maximal inhibitory concentration: > 100000 nM
Compound 3: no number, only a limit; the forecaster's own chance of this, stated with the estimate: 30%; the middle value lies beyond the limit too.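

Compound 3 gives > 100000 nM, which is a limit of the assay and not a number. For the compounds shown here, no step from compound 2 to compound 3 can be read. From the compounds shown here alone, whether 4-chlorophenyl in place of phenyl changes inhibition in this assay stays open.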